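A few compounds are considered here, and "the series" means these few. Any claim that something is new, unique, unknown or untested is made for them only; others in the source may bear on it.

Measured in a functional assay on PC-3 cells (Homo sapiens) for inhibition, read by MTT assay, with a stated time of 48 h; on this read-out higher numbers stand for weaker inhibition and lower numbers for stronger inhibition:
- compound 1 `COc1ccc(CSc2nnc(-c3cc(OC)c(OC)c(OC)c3)n2-c2ccc(OC)cc2)cc1`: 40300 nM
- compound 2 `COc1ccc(-n2c(SCc3ccc(F)cc3)nnc2-c2cc(OC)c(OC)c(OC)c2)cc1`: 35000 nM
- compound 3 `COc1ccc(C(=O)CSc2nnc(-c3cc(OC)c(OC)c(OC)c3)n2-c2ccc(OC)cc2)cc1`: > 60000 nM (a limit of the assay, not a number)

Compound 3 stands at the limit of > 60000 nM in this assay, at which 1 of the 3 values shown sits, so it has a limit and no exact number.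

Compound 4 `COc1ccc(NC(=O)CSc2nnc(-c3cc(OC)c(OC)c(OC)c3)n2-c2ccc(OC)cc2)cc1` has not been measured. It differs from compound 3 in one place, with (4-methoxyphenyl)amino in place of 4-methoxyphenyl on a carbonyl carbon. Among the measured compounds shown here, no measured step makes this exact change, so the nearest evidence comes from the three neighbouring compounds. The steps of an at least 1.4-fold higher number from compound 1 to compound 3 (0.17 log units; that floor lies within the scatter) and an at least 1.7-fold higher number from compound 2 to compound 3 (0.23 log units; that floor lies within the scatter) both have floors within the scatter, and a 1.2-fold lower number from compound 1 to compound 2 (0.06 log units; within the scatter) also lies within it. None of these steps is shown to exceed the scatter, so no large change is expected, although the limit on compound 3 leaves the true size open. The expected step is an at least 1.3-fold lower number from compound 3 to compound 4 (0.12 log units; that floor lies within the scatter), which is not expected to clearly exceed the scatter. Compound 4 is estimated at 45000 nM, with an expected range of 15000 nM to 90000 nM.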

Compound 4, half-maximal inhibitory concentration: 25800 nM
For compound 4 the middle estimate is 1.7-fold (0.24 log units) above the measured one, within the range that was stated.
By their numbers in this assay, from the lowest: compounds 4, 2 and 1 (each within the scatter of the next). At a limit, above all of these: compound 3.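

In this assay, (4-methoxyphenyl)amino in place of 4-methoxyphenyl on a carbonyl carbon gives the first step among these compounds that is shown to lie beyond the scatter, an at least 2.3-fold lower number from compound 3 to compound 4 (0.36 log units; beyond the scatter). That size is only a floor, because compound 3 carries a limit and not a number: the limit of > 60000 nM in this assay, at which 1 of the 4 values shown sits. Yet a 1.4-fold lower number from compound 2 to compound 4 (0.13 log units; within the scatter) and a 1.6-fold lower number from compound 1 to compound 4 (0.19 log units; within the scatter) both stay within the scatter, so on the saturated chain carbon bound to a sulfur, (4-methoxyphenyl)carbamoyl is set apart only from (4-methoxyphenyl)carbonyl, not from 4-fluorophenyl or 4-methoxyphenyl.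

The compounds shown leave open whether the amide hydrogen itself matters, which a methyl group on that nitrogen would test. They also leave open how a carboxylic acid or a longer chain at this carbonyl carbon would read.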